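The compounds below may be only part of what the source reports. "The series", "measured", "known", "first", "only" and "open" are said of these compounds alone.

Measured compounds in the permeability set:

Compound 1 `COc1ccccc1Oc1ccc2c(NCCCNCc3ccco3)ccnc2c1` gives 317 10^-6 cm/s in an ADME assay for permeability, using PAMPA, with a stated time of 30 min, at pH 7.4; a higher number here means that the compound crosses the layer faster, a lower number that the compound crosses the layer more slowly.
Compound 2 `COc1ccc(Oc2ccc3c(NCCCNCc4cc(F)ccc4OC)ccnc3c2)cc1` gives 317 10^-6 cm/s in this assay.
Compound 3 `COc1ccc(F)cc1CNCCCNc1ccnc2cc(Oc3ccc(F)cc3)ccc12` gives 317 10^-6 cm/s in this assay.

Compound 3 stands level with compounds 1 and 2 on the numbers shown; all three read the same value. Within the data shown here, the only measured step, no change at the digits printed from compound 2 to compound 3 (within the scatter), lies within the scatter. Among the measured compounds shown here, no step has been measured between compound 1 and compound 3, or between compound 1 and compound 2; their values show the same number.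

Compound 4 `COc1ccc(F)cc1CNCCCNc1ccnc2cc(Oc3ccccc3OC)ccc12` differs from compound 3 by 2-methoxyphenyl in place of 4-fluorophenyl on an oxygen on an aromatic ring. The step from compound 2 to compound 3 bears on this only in part: there, fluoro and methoxy were exchanged at an aromatic carbon, whereas here the whole group on the oxygen is exchanged, 4-fluorophenoxy to 2-methoxyphenoxy. Compound 1 already carries a 2-methoxyphenoxy group and reads the same value as compound 3. For the measured compounds named here, nothing among the measured compounds points to a step beyond the scatter in this assay, in either direction.

Compound 4 is therefore expected to read about 317 10^-6 cm/s in this assay, with a range of 160 10^-6 cm/s to 630 10^-6 cm/s. The implied step no change at the digits printed from compound 3 to compound 4 (within the scatter) is expected to stay within the scatter.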

Compound 4, apparent permeability: 317 10^-6 cm/s
Compound 4: middle estimate and measured number agree at the digits printed, within the range that was stated.
By their numbers in this assay, from the lowest: compounds 1, 2, 3 and 4 (each within the scatter of the next).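

In this assay the group on an oxygen on an aromatic ring now has a direct measured exchange, 2-methoxyphenyl in place of 4-fluorophenyl, and the result is no change at the digits printed from compound 3 to compound 4 (within the scatter) even though the entering group carries one hydrogen-bond acceptor and the leaving group none. At the same place, 2-methoxyphenyl in place of 4-methoxyphenyl gives no change at the digits printed from compound 2 to compound 4 (within the scatter) and so adds a comparison of two methoxyphenyl groups, while the other end of the molecule gains its first direct step, with 5-fluoro-2-methoxyphenyl in place of furan-2-yl on a saturated chain carbon bound to an amine nitrogen giving no change at the digits printed from compound 1 to compound 4 (within the scatter) as the outcome. No measurement shown gives a reason for these outcomes.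

All the exchanges shown are between aromatic groups, so the same read-out remains open for a carboxylic acid or an amine in place of 2-methoxyphenyl on the oxygen. Also open, from the compounds shown here alone, is a longer chain in place of the saturated chain that carries the amine nitrogen, with the 5-fluoro-2-methoxyphenyl group kept as in compound 4.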